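Swapping the side group of compound 3

The source may report more compounds than this note shows. Statements on the series, on what has been measured and on what is new or still open speak of the compounds shown alone.

Values in a physicochemical assay for solubility, read by nephelometry (a higher number here means a more soluble compound, a lower number a less soluble compound), so far:
- compound 1 `O=C1O[C@@H](Cn2ccnn2)CN1c1ccc(-c2ccc(CO)nc2)c(F)c1` gives 100000 nM
- compound 2 `COCc1ccc(-c2ccc(N3C[C@H](Cn4ccnn4)OC3=O)cc2F)cn1` gives 100000 nM
- compound 3 `O=C1O[C@@H](Cn2ccnn2)CN1c1ccc(-c2ccc(C(O)C3CNC3)nc2)c(F)c1` gives > 400000 nM

Compound 3 gives > 400000 nM and that is a limit of the assay, not a number. The data hold only one such case: the limit of > 400000 nM in this assay, at which 1 of the 3 values shown sits.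

Compound 4 `O=C(c1ccc(-c2ccc(N3C[C@H](Cn4ccnn4)OC3=O)cc2F)cn1)C1CCNCC1` differs from compound 3 in one place: (piperidin-4-yl)carbonyl in place of (azetidin-3-yl)(hydroxy)methyl on an aromatic carbon. In words, (piperidin-4-yl)carbonyl stands in place of (azetidin-3-yl)(hydroxy)methyl on an aromatic carbon.

Within the data shown here, three measured steps bear on this. Putting a methyl on the oxygen gave no change at the digits printed from compound 1 to compound 2 (within the scatter). The group that now leaves came with an at least 4.0-fold higher number from compound 1 to compound 3 (0.60 log units; beyond the scatter) and with an at least 4.0-fold higher number from compound 2 to compound 3 (0.60 log units; beyond the scatter). Among the measured compounds shown here, no measured step tests the entering group, so the gain seen in an at least 4.0-fold higher number from compound 2 to compound 3 (0.60 log units; beyond the scatter) may be partly lost or may hold. A modest fall or no change beyond the scatter is therefore expected. The expected size in this assay is an at least 1.4-fold lower number from compound 3 to compound 4 (0.15 log units; that floor lies within the scatter) as an estimate only. The estimate for compound 4 is 280000 nM with an expected range of 100000 nM to 400000 nM in this assay.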

Compound 4, solubility: 100000 nM
For compound 4 the middle estimate is 2.8-fold (0.45 log units) above the measured one; the measured number falls inside the stated range.
By their numbers in this assay, from the lowest: compounds 1, 2 and 4 (each within the scatter of the next). At a limit, above all of these: compound 3.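

In this assay, putting (piperidin-4-yl)carbonyl in place of (azetidin-3-yl)(hydroxy)methyl at this position gave an at least 4.0-fold lower number from compound 3 to compound 4 (0.60 log units; beyond the scatter), so a saturated ring with one nitrogen on this carbon does not by itself preserve the high reading of compound 3. Measured against the simpler groups, the same change gave no change at the digits printed from compound 2 to compound 4 (within the scatter) for methoxymethyl and no change at the digits printed from compound 1 to compound 4 (within the scatter) for hydroxymethyl, which places the larger ring-bearing group level with both. Compound 3 remains the only compound at a limit of the assay: the limit of > 400000 nM in this assay, at which 1 of the 4 values shown sits.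

The ring and the group linking it to the aromatic carbon change together, so the compounds shown cannot say which of the two matters. A (piperidin-4-yl)(hydroxy)methyl group or an (azetidin-3-yl)carbonyl group would separate these two changes.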